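The source may hold more compounds than are shown below. What is called first, only, known or untested is meant among the compounds shown, and "the series" means these compounds.

Within the data shown here, compound 3 `CCC(C(=O)N[C@@H](CC(=O)O)C(=O)CSCc1ccccc1)n1ccnc(NCc2cncs2)c1=O` gives 6590 nM in an assay for inhibition of Caspase-8 (Homo sapiens) (a lower number here means a stronger inhibitor, a higher number a weaker inhibitor), the second highest of the three numbers known. Compound 2 `CCC(C(=O)N[C@@H](CC(=O)O)C(=O)CSCc1ccccc1)n1ccnc(NCC2COc3ccccc3O2)c1=O` gives 8220 nM, and the step of a 1.2-fold lower number from compound 2 to compound 3 (0.10 log units; within the scatter) is within the scatter, whereas compound 1 `CCC(C(=O)N[C@@H](CC(=O)O)C(=O)CSCc1ccccc1)n1ccnc(NCc2cccs2)c1=O` gives 2090 nM, so that the step of a 3.2-fold higher number from compound 1 to compound 3 (0.50 log units; beyond the scatter) is beyond it. Compound 4 `CCC(C(=O)N[C@@H](CC(=O)O)C(=O)CSCc1ccccc1)n1ccnc(NCc2cc(C)no2)c1=O` differs from compound 3 by 3-methyl-1,2-oxazol-5-yl in place of 1,3-thiazol-5-yl on a saturated chain carbon bound to a nitrogen on an aromatic ring. Among the measured compounds shown here, the steps that bear on this are the swaps of one five-membered ring for another at that place: a 3.2-fold higher number from compound 1 to compound 3 (0.50 log units; beyond the scatter) and a 1.2-fold lower number from compound 2 to compound 3 (0.10 log units; within the scatter), one modest and one within the scatter. The step of a 1.1-fold higher number from compound 3 to compound 4 (0.03 log units; within the scatter) is therefore expected to be small, with no direction beyond the scatter. Compound 4 is estimated at 7000 nM, in the range 3000 nM to 18000 nM.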

Compound 4, half-maximal inhibitory concentration: 3300 nM
The estimate for compound 4 lay 2.1-fold (0.33 log units) above the measured number, within the range that was stated.
By their numbers in this assay, from the lowest: compounds 1, 4, 3 and 2 (each within the scatter of the next, the first and the last beyond it).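

In this assay, 3-methyl-1,2-oxazol-5-yl at this place lies within the scatter of both 1,3-thiazol-5-yl (a 2.0-fold lower number from compound 3 to compound 4 (0.30 log units; within the scatter)) and thiophen-2-yl (a 1.6-fold higher number from compound 1 to compound 4 (0.20 log units; within the scatter)), although those two groups lie beyond the scatter of each other. It separates only from 2,3-dihydro-1,4-benzodioxin-2-yl (a 2.5-fold lower number from compound 2 to compound 4 (0.40 log units; beyond the scatter)). The four compounds therefore form a chain of overlapping values, not distinct classes, and nothing shown explains the differences among them. As far as these compounds go, what a phenyl ring or an amine at this place would give remains open. So does the contribution of the methyl, since 1,2-oxazol-5-yl without it is not among the compounds shown.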